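Trading a 1-Phenylcyclobutyl for a Methyl on the Carbonyl

The source may hold more compounds than are shown below. What is called first, only, known or untested is meant among the compounds shown, and "the series" means these compounds.

Compound 1 `NCCNc1cc(N2CCN(C(=O)C3(c4ccccc4)CCC3)CC2)nc2ccccc12` was examined in an ADME assay on HEp-2 cells (Homo sapiens) for cytotoxicity, read by CCK-8 assay, with a stated time of 6 days; on this read-out lower numbers stand for higher toxicity in this test and higher numbers for lower toxicity in this test. In this assay compound 1 gives > 100000 nM, which is a limit of the assay rather than a measured number. Two relatives sharing the same core were run in the same test. Compound 2 `CS(=O)(=O)N1CCN(c2cc(NCCN)c3ccccc3n2)CC1` gives > 100000 nM in this assay, again a limit. Compound 3 `NCCNc1cc(N2CCN(C(=O)C3(c4ccccc4)CC3)CC2)nc2ccccc12` gives > 100000 nM in this assay, also a limit. The only single-point step among these three, a step that the two limits leave unreadable from compound 1 to compound 3, is therefore unreadable: both ends sit at the limit, so the effect of shrinking the four-membered ring to a three-membered one cannot be sized. Because (the limit of > 100000 nM in this assay, at which 3 of the 3 values shown sit), every compound measured here shows no detectable toxicity within the tested range.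

Compound 4 `CC(=O)N1CCN(c2cc(NCCN)c3ccccc3n2)CC1` differs from compound 1 by methyl in place of 1-phenylcyclobutyl on a carbonyl carbon. For the measured compounds named here, no measured step follows exactly this change; the step from compound 1 to compound 3, which also removes mass at the same carbonyl carbon, left the limit untouched. Compound 4 is accordingly expected to give 200000 nM in this assay, with a plausible range from 80000 nM to 1000000 nM. The expected step from compound 1 to compound 4 is a step that the limit leaves unreadable from compound 1 to compound 4, meaning no change that the assay could read.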

Compound 4, half-maximal cytotoxic concentration: > 100000 nM
Compound 4 ended at the assay's limit (the forecaster's own chance of this, stated with the estimate: 90%); the middle value does not contradict the limit.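

In this assay the steps from compound 1, compound 2 and compound 3 to compound 4 cannot be read, since both ends of each step are limits and not numbers: the limit of > 100000 nM in this assay, at which 4 of the 4 values shown sit.

Whether the groups that vary among compound 1, compound 2, compound 3 and compound 4 differ at all in toxicity stays open, as does the concentration at which any of these compounds would begin to harm the cells.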